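The source may report more compounds than this note shows. Statements on the series, on what has been measured and on what is new or still open speak of the compounds shown alone.

Measured compounds:
Compound 1 `Cc1ccc(-n2c(=O)n(-c3ccc(C#N)c(C(F)(F)F)c3)c3ccccc32)cc1` gives 790 nM in a physicochemical assay for solubility; a lower number here means a less soluble compound, a higher number a more soluble compound.
Compound 2 `CNC(=O)c1ccc(-c2ccc3c(c2)C(C)(C)C(=O)N3c2ccc(C#N)c(OC)c2)cc1F` gives 9700 nM in this assay.
Compound 3 `CC(c1nc(-c2ccccn2)no1)n1c(=O)n(-c2ccc(C#N)c(Cl)c2)c2ccccc21` gives 9450 nM in this assay.

Among these three, compound 1 has the lowest number in this assay. Compound 3 stands nearest to it, yet its number is higher by a margin beyond the usual scatter; compound 2 lies higher still, also beyond the scatter. Compound 1 is therefore the least soluble of the three as measured here.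

Compound 4 `N#Cc1ccc(-n2c(=O)n(Cc3ccccn3)c3ccccc32)cc1C(F)(F)F` has not yet been measured in this assay. It differs from compound 1 in one place: (pyridin-2-yl)methyl in place of 4-methylphenyl on an aromatic nitrogen. The leaving group carries no hydrogen-bond acceptor, the entering one carries one, as counted in that difference.

Among the measured compounds shown here, no step between two measured compounds covers this kind of change, so the expectation rests on the value of compound 1 alone. The account expects a moderate rise in this assay, a step of a 3.2-fold higher number from compound 1 to compound 4 (0.50 log units; beyond the scatter), though a result within the scatter would not be surprising. For compound 4 the estimate in this assay is 2500 nM, with a range from 800 nM to 8000 nM.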

Compound 4, solubility: 12000 nM
Compound 4: middle estimate off by 4.8-fold (0.68 log units), on the low side; the whole stated range lies below it.
By their numbers in this assay, from the lowest: compound 1; then compounds 3, 2 and 4 (each within the scatter of the next).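

With (pyridin-2-yl)methyl in place of 4-methylphenyl on the aromatic nitrogen, this assay shows a large step, a 15-fold higher number from compound 1 to compound 4 (1.18 log units; beyond the scatter) and thus gives the first reading of a single change among these compounds. This place on the shared core is therefore not indifferent to the group it carries, at least for this pair. The step comes with no change in the heavy-atom count of the group, while the entering group holds a hydrogen-bond acceptor that the leaving one lacks and also sets a carbon link between its ring and the core.

The compounds shown do not separate the ring nitrogen from that carbon link, and a benzyl group on the same nitrogen would pull the two apart. Nothing available speaks to the cause of the step.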